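The source may hold more compounds than are shown below. What is called first, only, known or untested is meant among the compounds shown, and "the series" means these compounds.

Compound 1 `COc1ccc(-c2cnc3nc(N)nc(N4CCN(C(=O)COc5ccccc5)CC4)c3n2)cc1OC` gives 4 nM in a functional assay on cells (T-cell, Homo sapiens) for inhibition; on this read-out higher numbers stand for weaker inhibition and lower numbers for stronger inhibition. Compound 2 `COc1ccc(-c2cnc3nc(N)nc(N4CCN(c5cc(Cl)cc(Cl)c5)CC4)c3n2)cc1OC` gives 3400 nM in this assay, and compound 3 `COc1ccc(-c2cnc3nc(N)nc(N4CCN(Cc5ccc(C(C)(C)C)cc5)CC4)c3n2)cc1OC` gives 4300 nM. Compound 3 therefore carries the highest number of the three, meaning the weakest inhibition; compound 2 sits within the usual scatter of it, while compound 1 lies far below it, as a 1100-fold higher number from compound 1 to compound 3 (3.03 log units; beyond the scatter) shows. Compound 4 `COc1ccc(-c2cnc3nc(N)nc(N4CCN(C(=O)CCc5ccccc5)CC4)c3n2)cc1OC` differs from compound 3 in one place: phenethylcarbonyl in place of 4-(tert-butyl)benzyl on an amine nitrogen in a ring. The entering group carries a carbonyl on the ring nitrogen, as does the group of compound 1, whereas the leaving group does not. Within the data shown here, two measured steps bear on this. The step of a 1100-fold higher number from compound 1 to compound 3 (3.03 log units; beyond the scatter), in which a carbonyl-bearing group gave way to a benzyl group, was large; the step of a 1.3-fold higher number from compound 2 to compound 3 (0.10 log units; within the scatter), between two groups without a carbonyl, stayed within the scatter. Compound 4 is therefore expected to show a large step toward stronger inhibition, a 360-fold lower number from compound 3 to compound 4 (2.55 log units; beyond the scatter) in this assay. Compound 4 is estimated at 12 nM, within a range from 2 nM to 80 nM.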

Compound 4, half-maximal inhibitory concentration: 100 nM
Compound 4: middle estimate off by 8.3-fold (0.92 log units), on the low side; the whole stated range lies below it.
By their numbers in this assay, from the lowest: compound 1; then compound 4; then compounds 2 and 3 (each within the scatter of the next).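

In this assay, compound 4 recovers much of the inhibition lost with the groups lacking a carbonyl on the ring nitrogen, with a 43-fold lower number from compound 3 to compound 4 (1.63 log units; beyond the scatter) and a 34-fold lower number from compound 2 to compound 4 (1.53 log units; beyond the scatter), so the very low number of compound 1 is not the only case of a carbonyl-bearing group doing better. The carbonyl does not settle the number on its own, however: with benzyl in place of phenoxy on the saturated chain carbon bound to the carbonyl carbon, there is a 25-fold higher number from compound 1 to compound 4 (1.40 log units; beyond the scatter), so this part of the chain also matters. No measurement given here explains either difference.

A 3-phenylpropyl group, with carbon in place of the carbonyl, would test the carbonyl directly against compound 4. On these data alone, how a chain carrying an amine nitrogen in place of the phenoxy oxygen would compare with compound 1 remains open.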